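Adding a third fluorine to the benzyl group of compound 3

The compounds below may be only part of what the source reports. "The series", "measured", "known", "first", "only" and "open" are said of these compounds alone.

Of the compounds shown here, three share one core and have been tested in an ADME assay on MT4 cells (Homo sapiens) for cytotoxicity, read by MTT assay; on this read-out lower numbers stand for higher toxicity in this test and higher numbers for lower toxicity in this test. Compound 1, `COc1cccc2c1c(C(=O)/C=C(\O)C(=O)O)cn2Cc1cccc(F)c1F`, gives 17500 nM in this assay. Compound 2, `COc1cccc2c1c(C(=O)/C=C(\O)C(=O)O)cn2Cc1cc(F)cc(F)c1`, gives 29500 nM in this assay. Compound 3, `CCOC(=O)/C(O)=C/C(=O)c1cn(Cc2cccc(F)c2F)c2cccc(OC)c12`, gives 21100 nM in this assay. The step of a 1.7-fold higher number from compound 1 to compound 2 (0.23 log units; within the scatter) swaps one difluorophenyl pattern for another, and the step of a 1.2-fold higher number from compound 1 to compound 3 (0.08 log units; within the scatter) turns the free acid into its ethyl ester. Both steps stay inside the scatter, so the three numbers cannot be ordered with confidence; compound 3 sits at the second highest of the three, nearest to compound 1.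

Compound 4, `CCOC(=O)/C(O)=C/C(=O)c1cn(Cc2ccc(F)c(F)c2F)c2cccc(OC)c12`, differs from compound 3 by fluoro in place of hydrogen on an aromatic carbon. Going by the values given here, no measured step touches this exact change, but the one change on the same benzyl ring, the step from compound 1 to compound 2, stayed within the scatter, as did the change at the ester. Compound 4 is therefore expected to show no step beyond the scatter, a 1.0-fold higher number from compound 3 to compound 4 (0.02 log units; within the scatter), with an estimate of 22000 nM in this assay and a range from 10000 nM to 48000 nM.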

Compound 4, half-maximal cytotoxic concentration: 42700 nM
The estimate for compound 4 lay 1.9-fold (0.29 log units) below the measured number; measured number inside the range.
By their numbers in this assay, from the lowest: compounds 1, 3, 2 and 4 (each within the scatter of the next, the first and the last beyond it).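

In this assay the added fluoro gives a 2.0-fold higher number from compound 3 to compound 4 (0.31 log units; beyond the scatter) which is the first step among these compounds to pass beyond the scatter, although only modestly, and it points towards lower toxicity in this test. The position para to a large group and ortho to a fluoro group therefore responds to this small change: going from 2,3-difluorobenzyl to 2,3,4-trifluorobenzyl moves the number more than the earlier changes on the benzyl ring or at the ester could be shown to do. Nothing measured here accounts for the rise.

Going by these compounds, whether a chloro or a methyl group at this same position would move the number in the same direction remains open. So does whether the same added fluoro would give a similar step on the free carboxylic acid of compound 1 rather than on the ethyl ester.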